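From Hydroxy to Chloro with Cytotoxicity at the Assay Limit

The source may hold more compounds than are shown below. What is called first, only, known or untested is meant among the compounds shown, and "the series" means these compounds.

Compound 1, `COc1ccc(C(=O)/C=C/c2cc3ccccc3[nH]c2=O)cc1`: > 100000 nM in an ADME assay on NCI/ADR-RES cells (Homo sapiens) for cytotoxicity, read by sulforhodamine B assay, with a stated time of 24 h; a lower number here means that less compound is tolerated, a higher number that more compound is tolerated
Compound 2, `O=C(/C=C/c1cc2ccccc2[nH]c1=O)c1ccc(O)cc1`: > 100000 nM

Compound 1 sits at a limit of the assay. Compound 2 also sits at a limit of the assay, so its standing is known only as a limit. The step that the two limits leave unreadable from compound 1 to compound 2 cannot be sized because of the limit of > 100000 nM in this assay, at which 2 of the 2 values shown sit.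

Compound 3, `O=C(/C=C/c1cc2ccccc2[nH]c1=O)c1ccc(Cl)cc1`, differs from compound 2 by chloro in place of hydroxy on an aromatic carbon, that is 4-hydroxyphenyl to 4-chlorophenyl. Among the compounds with values here, no measured step reads this change. Compound 3 is therefore expected to remain at the limit, estimated at 150000 nM with a range from 50000 nM to 500000 nM. The expected step is a step that the limit leaves unreadable from compound 2 to compound 3, none beyond the scatter.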

Compound 3, concentration lethal to 50% of the cells: > 100000 nM
Compound 3: no number, only a limit (the forecaster's own chance of this, stated with the estimate: 80%); the middle value lies beyond the limit too.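

Within the data shown here, compound 3 gives > 100000 nM in this assay, which is a limit of the assay and not a number, so no step from compound 1 or compound 2 to compound 3 can be read: the limit of > 100000 nM in this assay, at which 3 of the 3 values shown sit.

The compounds shown leave open whether compound 1, compound 2 and compound 3 differ at all in this assay.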